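A few compounds are considered here, and "the series" means these few. Any claim that something is new, unique, unknown or untested is made for them only; others in the source may bear on it.

Working notes on the series.

Of the compounds shown here, two have numbers so far. Compound 1 `COc1ccccc1C(=O)NCCCNc1nc2cc(C)cc(C)c2cc1C#N` gives 100000 nM in an assay on cells with Cystic fibrosis transmembrane conductance regulator variant F508del (Homo sapiens) as the target, read by fluorescence, with stated times of 24 h and 30 min; on this read-out lower numbers stand for an effect already at smaller amounts and higher numbers for an effect only at larger amounts of compound. Compound 2 `CC(=O)NCCCNc1nc(-c2ccccn2)nc2c1CN(Cc1ccc(F)cc1)CC2` gives 200 nM in this assay and so stands with the lowest of the two numbers; the gap to compound 1 lies beyond the scatter, but the two compounds differ in more than one place, so the two values are simply taken as they stand and no single change is tied to the gap.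

Compound 3 `CN(C)CCN1CCN(c2nc(-c3ccccn3)nc3c2CN(Cc2ccc(F)cc2)CC3)CC1` has not yet been measured. It differs from compound 2 in one place: 4-(2-(dimethylamino)ethyl)piperazin-1-yl in place of (3-acetamidopropyl)amino on an aromatic carbon. The change trades a chain carrying two hydrogen-bond donors for a ring group carrying none, and nothing in the measured pair speaks to such a swap.

Within the data shown here, with no measured step of this kind, the expectation rests on the value of compound 2 alone, taken as the starting point, and on a general reading that the loss of the (3-acetamidopropyl)amino group will more likely cost than gain. The step from compound 2 to compound 3 is expected to be a 7.5-fold higher number from compound 2 to compound 3 (0.88 log units; beyond the scatter), toward a higher number, with a wide range. Compound 3 is estimated at 1500 nM in this assay, between 300 nM and 10000 nM.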

Compound 3, half-maximal effective concentration: 100000 nM
The estimate for compound 3 lay 67-fold (1.82 log units) below the measured number, outside the stated range (above it).
By their numbers in this assay, from the lowest: compound 2; then compounds 1 and 3 (each within the scatter of the next).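

The position on the aromatic carbon next to the ring nitrogen proves highly sensitive in this assay to the group it carries: 4-(2-(dimethylamino)ethyl)piperazin-1-yl in place of (3-acetamidopropyl)amino gives a 500-fold higher number from compound 2 to compound 3 (2.70 log units; beyond the scatter) with the rest of the structure unchanged. Among these compounds, this is the first change in one place, so the position can now be tied to a large change in the number, which the comparison of compound 1 with compound 2 could not do; the open chain with its hydrogen-bond donors leaves, and a group with a non-aromatic ring and no hydrogen-bond donors enters, but this single step does not separate those differences. Nothing measured here bears on the reason for the step.

Still open, from the compounds shown here alone, is which part of the (3-acetamidopropyl)amino group matters, a question that a terminal primary amine in place of the acetamide, or a shorter or longer chain between the two nitrogens, would address. A simple 4-methylpiperazin-1-yl group at the same position would also show whether the piperazine ring or the dimethylaminoethyl arm goes with the higher number.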